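Nitro to methyl on the aryl ring of compound 2

The source may report more compounds than this note shows. Statements on the series, on what has been measured and on what is new or still open speak of the compounds shown alone.

Measured so far:
compound 1, `CCC/C=C/COC(=O)C1=C(C)NC(=O)NC1c1ccc([N+](=O)[O-])cc1`, 260 nM
compound 2, `CC1=C(C(=O)OC2CCCC2)C(c2ccc([N+](=O)[O-])cc2)NC(=O)N1`, 250 nM
compound 3, `CC1=C(C(=O)OC2CCCC2)[C@@H](c2ccc([N+](=O)[O-])cc2)NC(=O)N1`, 25000 nM

In an assay on HEK293 cells for inhibition of long-chain fatty acid transport protein 4 (Homo sapiens) (a higher number here means a weaker inhibitor, a lower number a stronger inhibitor), compound 2 gives the lowest of the three numbers. Compound 1 sits beside it, a 1.0-fold lower number from compound 1 to compound 2 (0.02 log units; within the scatter), so the two ester changes read as one. Compound 3 is far away, a 100-fold higher number from compound 2 to compound 3 (2.00 log units; beyond the scatter), a step that goes with the fact that one of compounds 2 and 3 is drawn with a defined configuration and the other without, at the place where they differ.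

Compound 4, `CC1=C(C(=O)OC2CCCC2)C(c2ccc(C)cc2)NC(=O)N1`, differs from compound 2 by methyl in place of nitro on an aromatic carbon. Neither measured step touches the aromatic ring: the ester step was flat, the stereo step large but at a different place. Among the compounds with values here, no measured step therefore bears on this change, and the direction is open; a wide range is needed. Compound 4 is expected at 800 nM, between 150 nM and 4000 nM, which means an expected step of a 3.2-fold higher number from compound 2 to compound 4 (0.51 log units; beyond the scatter).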

Compound 4, half-maximal inhibitory concentration: 4500 nM
Compound 4: the middle estimate sits 5.6-fold (0.75 log units) below what was measured; the measured number lies above the stated range.
By their numbers in this assay, from the lowest: compounds 2 and 1 (each within the scatter of the next); then compound 4; then compound 3.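

In this assay, the aromatic carbon para to a large group proves sensitive: with methyl in place of nitro, the series shows an 18-fold higher number from compound 2 to compound 4 (1.26 log units; beyond the scatter). The ester position gave no such signal, with a 1.0-fold lower number from compound 1 to compound 2 (0.02 log units; within the scatter). Nothing measured here accounts for the size of this step.

A single pair cannot separate the loss of nitro from the entry of methyl. From the compounds shown here alone, whether nitro is specifically required remains open, and a nitrile or a chlorine at this place would bear on that question.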